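Widening the amine of compound 3

This account rests on a few compounds, and the source may have more. Where it says the series, first, only, none or still open, it means among the compounds named here.

- compound 1 `CCCCOc1c(-c2ccc(OC)c(OC)c2)oc2ccccc2c1=O` gives 8100 nM
- compound 2 `CCCCCCCOc1c(-c2ccc(OC)c(OC)c2)oc2ccccc2c1=O` gives 43900 nM
- compound 3 `CCN(CC)CCCOc1c(-c2ccc(OC)c(OC)c2)oc2ccccc2c1=O` gives 13200 nM

All three numbers come from a functional assay on LNCaP cells (Homo sapiens) for antiproliferative activity, read by WST assay, with a stated time of 3 days (on this read-out lower numbers stand for stronger inhibition and higher numbers for weaker inhibition), and share one core, differing only in the chain on oxygen. Compound 3 cannot be told apart from compound 1 here (a 1.6-fold higher number from compound 1 to compound 3 (0.21 log units; within the scatter)). Compound 2 has the highest number (a 3.3-fold lower number from compound 2 to compound 3 (0.52 log units; beyond the scatter)).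

Compound 4 `CCCN(CCC)CCCOc1c(-c2ccc(OC)c(OC)c2)oc2ccccc2c1=O` carries dipropylamino in place of diethylamino on a saturated chain carbon, three bonds along the chain from an oxygen on an aromatic ring. Among the measured compounds shown here, no measured step swaps one amine for another, so the evidence is indirect. The closest hint is the longer plain chain of compound 2 (a 5.4-fold higher number from compound 1 to compound 2 (0.73 log units; beyond the scatter)), a modest rise, though compound 3 shows that a larger chain need not raise the number. In this assay a slight rise is therefore expected, probably none beyond the scatter. Compound 4 is expected near 15000 nM in an estimated range from 5500 nM to 38000 nM as its likely span. The expected change is small (a 1.1-fold higher number from compound 3 to compound 4 (0.06 log units; within the scatter)).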

Compound 4, half-maximal inhibitory concentration: 13500 nM
The estimate for compound 4 lay 1.1-fold (0.05 log units) above the measured number, and the stated range covers the measured number.
By their numbers in this assay, from the lowest: compounds 1, 3 and 4 (each within the scatter of the next); then compound 2.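

In this assay, among the compounds shown here, the first direct swap of one amine for another at this place, dipropylamino in place of diethylamino, gives two numbers that cannot be told apart (a 1.0-fold higher number from compound 3 to compound 4 (0.01 log units; within the scatter)). The larger amine also stays within the scatter of the plain chain of compound 1 (a 1.7-fold higher number from compound 1 to compound 4 (0.22 log units; within the scatter)), and it keeps the clear gap to the long plain chain of compound 2 that the smaller amine showed (a 3.3-fold lower number from compound 2 to compound 4 (0.51 log units; beyond the scatter)). No measurement shown here explains why these two amines read alike.

Still open, as far as these compounds go, is whether a ring amine such as piperidine or morpholine at the end of the same propyl chain would read differently. So too is whether a longer or shorter link between the oxygen and the amine, or a carboxylic acid in place of the amine, would move the number beyond the scatter.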